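A few compounds are considered here, and "the series" means these few. Any claim that something is new, unique, unknown or untested is made for them only; others in the source may bear on it.

Measured compounds:
compound 1, `CCc1cc(/C=C/C(=O)c2ccccc2NC(=O)NS(=O)(=O)c2ccc(C)cc2)cc(OC)c1OC`, 19.2 ug/mL
compound 2, `Cc1ccc(S(=O)(=O)NC(=O)Nc2ccccc2C(=O)/C=C/c2ccc(O)cc2)cc1`, 24.3 ug/mL
compound 3, `Cc1ccc(S(=O)(=O)NC(=O)Nc2ccccc2C(=O)/C=C/c2cccc(Br)c2)cc1`, 4.02 ug/mL

These three were measured in an ADME assay on the whole organism for cytotoxicity, with Artemia salina as the target, with a stated time of 24 h; a lower number here means that less compound is needed, a higher number that more compound is needed for the effect. Compound 2 gives the highest of the three numbers. For the measured compounds named here, the step of a 1.3-fold higher number from compound 1 to compound 2 (0.10 log units; within the scatter) lies within the scatter, so compounds 1 and 2 cannot be told apart, while the step of a 6.0-fold lower number from compound 2 to compound 3 (0.78 log units; beyond the scatter) is the only step from compound 2 that goes beyond the scatter.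

Compound 4, `C=CCOc1ccc(/C=C/C(=O)c2ccccc2NC(=O)NS(=O)(=O)c2ccc(C)cc2)cc1`, has not yet been measured. It differs from compound 2 in a single place: allyl in place of hydrogen on an oxygen on an aromatic ring. Going by the values given here, no measured pair caps the hydroxy group in this way, so there is no direct guide. The closest comparison is the step of a 1.3-fold higher number from compound 1 to compound 2 (0.10 log units; within the scatter), where a ring carrying methoxy groups and a ring carrying a hydroxy group gave numbers within the scatter of each other. The step of a 6.0-fold lower number from compound 2 to compound 3 (0.78 log units; beyond the scatter) involves a bromine-bearing ring and does not speak to an oxygen substituent. I therefore expect the step of a 1.4-fold lower number from compound 2 to compound 4 (0.16 log units; within the scatter) to stay within the scatter. For compound 4 the estimated value in this assay is 17 ug/mL, with a range from 8 ug/mL to 36 ug/mL.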

Compound 4, concentration for half-maximal effect: 6.11 ug/mL
For compound 4 the middle estimate is 2.8-fold (0.44 log units) above the measured one; the whole stated range lies above it.
By their numbers in this assay, from the lowest: compounds 3 and 4 (each within the scatter of the next); then compounds 1 and 2 (each within the scatter of the next).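

Capping the hydroxy oxygen with allyl changes the number in this assay by more than the scatter (a 4.0-fold lower number from compound 2 to compound 4 (0.60 log units; beyond the scatter)), so this oxygen is a position where a change on the ring can register, which no earlier pair showed. The allyloxy ring also separates from the ethyl- and methoxy-bearing ring (a 3.1-fold lower number from compound 1 to compound 4 (0.50 log units; beyond the scatter)), yet it cannot be told apart from the 3-bromophenyl ring (a 1.5-fold higher number from compound 3 to compound 4 (0.18 log units; within the scatter)), so two quite different rings give numbers within the scatter of each other. No measurement here explains why the allyl step has this size.

From the compounds shown here alone, it remains open whether the double bond of allyl matters, which a propyl group on the same oxygen could test. A longer chain such as hexyl, or an amine in place of the oxygen, would show how far this effect extends.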